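Moving the nitrile on the pyridine ring of a P2X7 antagonist

The source may report more compounds than this note shows. Statements on the series, on what has been measured and on what is new or still open speak of the compounds shown alone.

Measured compounds:
- compound 1 `O=C(NCC1(O)CCCCCC1F)c1cc(-c2ncc(F)cn2)ccc1Cl`: 17 nM
- compound 2 `N#Cc1cccc(-c2ccc(Cl)c(C(=O)NCC3(O)CCCCCC3)c2)n1`: 232 nM

Of the compounds shown here, two have been tested in a functional assay on HEK293 cells for antagonist activity at P2X purinoceptor 7 (Homo sapiens); on this read-out higher numbers stand for weaker inhibition and lower numbers for stronger inhibition. Compound 1 gives 17 nM, while compound 2 gives 232 nM, the higher of the two numbers; the gap between them is well beyond the usual scatter, so compound 2 is the weaker inhibitor of the pair. The two differ in more than one place, so nothing about a single change can be read from that gap.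

Compound 3 `N#Cc1ccc(-c2ccc(Cl)c(C(=O)NCC3(O)CCCCCC3)c2)nc1` has the same atoms as compound 2, joined differently: 5-cyanopyridin-2-yl in place of 6-cyanopyridin-2-yl on an aromatic carbon. The nitrile is shifted from one position on the pyridine ring to another, at the aromatic carbon of the shared core that is meta to a large group and para to a chloro group.

Among the measured compounds shown here, no measured pair shows this exact change, so the expected step in this assay is uncertain. Compound 1, whose six-membered heteroaromatic ring carries its small substituent in a corresponding outer position, gives 17 nM, which suggests that moving the nitrile outward may lower the number. A moderate step downward is expected in this assay for compound 3, estimated at a 3.9-fold lower number from compound 2 to compound 3 (0.59 log units; beyond the scatter), giving an expected value of 60 nM, within a range from 15 nM to 250 nM.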

Compound 3, half-maximal inhibitory concentration: 134 nM
Compound 3: the middle estimate sits 2.2-fold (0.35 log units) below what was measured; low and high end bracket the measured number.
By their numbers in this assay, from the lowest: compound 1; then compounds 3 and 2 (each within the scatter of the next).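

In this assay, among the compounds shown here, putting 5-cyanopyridin-2-yl in place of 6-cyanopyridin-2-yl, on the aromatic carbon para to a chloro group, gives a 1.7-fold lower number from compound 2 to compound 3 (0.24 log units; within the scatter) in the first pair of this series that differs in one place only. The two compounds have the same atoms and the same counts of donors and acceptors, and shifting the nitrile along the pyridine ring does not separate them in this read-out, so at this position the change shows no effect that can be told from repeat-measurement noise. No outside measurement here offers any account of this result.

Compound 1 differs from compound 2 and compound 3 in more than one place, so the steps from it cannot be read, and the source of its lower number remains unresolved. Also open, going by these compounds, is whether a different group at this place on the pyridine ring, such as a methoxy group, a primary amine or a carboxylic acid, would move the number beyond the scatter, which the two nitrile compounds cannot settle.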